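Methoxy for fluoro on the imine-side ring of compound 3

The compounds below may be only part of what the source reports. "The series", "measured", "known", "first", "only" and "open" are said of these compounds alone.

Three pyrazoline amides of a shared core have been measured in an assay on isolated protein for inhibition of Amine oxidase [flavin-containing] B (Bos taurus); on this read-out higher numbers stand for weaker inhibition and lower numbers for stronger inhibition. Compound 1 `CCC(=O)N1N=C(c2ccc(Cl)cc2)CC1c1ccc(Cl)cc1` gives 10000 nM, compound 2 `CCC(=O)N1N=C(c2ccc(F)cc2)CC1c1ccc(Cl)cc1` gives 6310 nM, and compound 3 `CCC(=O)N1N=C(c2ccc(F)cc2)CC1c1ccc(C)cc1` gives 151 nM. Compound 3 stands lowest of the three, and as both steps toward it are beyond the scatter, it is the most potent compound measured: compound 2 lies a 42-fold lower number from compound 2 to compound 3 (1.62 log units; beyond the scatter) and compound 1 lies further still.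

Compound 4 `CCC(=O)N1N=C(c2ccc(OC)cc2)CC1c1ccc(C)cc1` differs from compound 3 in one place: methoxy in place of fluoro on an aromatic carbon. Within the data shown here, only one measured step touches the same ring, the exchange of a 1.6-fold lower number from compound 1 to compound 2 (0.20 log units; within the scatter), and that step stayed within the scatter. The large step from compound 2 to compound 3 concerns the other ring and does not speak to a methoxy group. No measured compound carries a methoxy group anywhere, so the direction of this change is not shown by the data.

Among the measured compounds shown here, with one small halogen swap on this ring as the only guide, the expected step of a 1.7-fold higher number from compound 3 to compound 4 (0.22 log units; within the scatter) is small and may not exceed the scatter. Compound 4 is therefore estimated at 250 nM in this assay, with a range from 70 nM to 900 nM.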

Compound 4, half-maximal inhibitory concentration: 10000 nM
Compound 4: the middle estimate sits 40-fold (1.60 log units) below what was measured; the measured number lies above the stated range.
By their numbers in this assay, from the lowest: compound 3; then compounds 2, 1 and 4 (each within the scatter of the next).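

In this assay, the change from 4-fluorophenyl to 4-methoxyphenyl gives a 66-fold higher number from compound 3 to compound 4 (1.82 log units; beyond the scatter). Among these compounds, this shows that the position is far from indifferent to what it carries, although the only earlier exchange on this ring, a 1.6-fold lower number from compound 1 to compound 2 (0.20 log units; within the scatter), had suggested little sensitivity there. It also shows that the methyl group on the other ring does not secure a low number by itself, since compound 3 and compound 4 share that methyl group and still lie far apart. No measurement shown here explains why methoxy behaves so differently from fluoro at this position.

The compounds shown leave open whether the step belongs to methoxy alone or extends to other groups at this position, such as a hydroxyl, an ethoxy or an amine, or a plain methyl that would test the same place without the oxygen. Among the compounds shown here, they also leave open whether chloro and fluoro remain interchangeable on this ring when the other ring carries methyl, since their only comparison has chloro on that other ring.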